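The compounds below may be only part of what the source reports. "The series", "measured", "known", "first", "only" and "open" are said of these compounds alone.

Measured in a functional assay on MCF-10A cells (Homo sapiens) for antiproliferative activity, with a stated time of 48 h; on this read-out lower numbers stand for an effect already at smaller amounts and higher numbers for an effect only at larger amounts of compound:
- compound 1 `COc1ccc2nc(C)cc(NCc3cccnc3)c2c1`: 44800 nM
- compound 2 `COc1ccc2nc(C)cc(NCC3CCCN(C)C3)c2c1`: 6400 nM

Of these two numbers, the lower belongs to compound 2. Going by the values given here, the only measured step is a 7.0-fold lower number from compound 1 to compound 2 (0.85 log units; beyond the scatter); it is modest, lies beyond the scatter, and comes with 1-methylpiperidin-3-yl in place of pyridin-3-yl on a saturated chain carbon bound to a nitrogen on an aromatic ring.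

Compound 3 `COc1ccc2nc(C)cc(NCc3cccc(F)c3)c2c1` has not yet been measured. Its difference from compound 2 is 3-fluorophenyl in place of 1-methylpiperidin-3-yl on a saturated chain carbon bound to a nitrogen on an aromatic ring. The same 1-methylpiperidin-3-yl leaves, and 3-fluorophenyl enters at the same place.

Among the compounds with values here, that measured step is the only one bearing on this change, and it is a weak guide, as 3-fluorophenyl is not pyridin-3-yl. Still, the entering group has an aromatic ring, as does the group in compound 1, which gives 44800 nM. A higher number is therefore expected in this assay. The expected move is a 3.4-fold higher number from compound 2 to compound 3 (0.54 log units; beyond the scatter), somewhat smaller than the measured step.

For compound 3 the estimated value is 22000 nM, with an expected range of 7000 nM to 65000 nM.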

Compound 3, half-maximal effective concentration: 11300 nM
For compound 3 the middle estimate is 1.9-fold (0.29 log units) above the measured one; the measured number falls inside the stated range.
By their numbers in this assay, from the lowest: compounds 2 and 3 (each within the scatter of the next); then compound 1.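

In this assay the step of a 1.8-fold higher number from compound 2 to compound 3 (0.25 log units; within the scatter) shows that on a saturated chain carbon bound to a nitrogen on an aromatic ring, 3-fluorophenyl and 1-methylpiperidin-3-yl cannot be told apart, so an aromatic ring at this place does not by itself go with the high number of compound 1. The step of a 4.0-fold lower number from compound 1 to compound 3 (0.60 log units; beyond the scatter) separates the two aromatic groups, which places the gap within this set of three on pyridin-3-yl against 3-fluorophenyl rather than on aromatic against non-aromatic rings. No measurement at hand explains either step.

From the compounds shown here alone, whether the fluorine has any part in the gap to pyridin-3-yl stays open, and plain phenyl or 3-chlorophenyl on the same chain carbon would bear on that. Also open, going by these compounds, is how far the result for 1-methylpiperidin-3-yl extends to other saturated amines at this place, such as piperidin-3-yl without the methyl group or a dimethylaminoethyl chain.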